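The source may hold more compounds than are shown below. What is called first, only, known or untested is meant among the compounds shown, and "the series" means these compounds.

In a functional assay (strain AB) with Danio rerio as the target, read by microscopy, with a stated time of 1 h (a higher number here means that more compound is needed for the effect, a lower number that less compound is needed), compound 1 `CCN1CCc2c(sc(NC=O)c2C(N)=O)C1` gives > 25000 nM as a limit of the assay. Compound 2 `CCN1CCc2c(sc(NC(=O)Nc3ccc(Cl)cc3)c2C(=O)NC)C1` gives > 25000 nM, also a limit and not a number, so it has no exact place on the scale (it stands with the limit of > 25000 nM in this assay, at which 2 of the 2 values shown sit). Compound 3 `CCN1CCc2c(sc(NC(=O)Nc3ccc(Cl)cc3)c2C(=O)c2nnco2)C1` carries 1,3,4-oxadiazol-2-yl in place of methylamino on a carbonyl carbon and is otherwise the same as compound 2. Within the data shown here, no measured step bears on this change. The estimated at least 1.2-fold lower number from compound 2 to compound 3 (0.09 log units; that floor lies within the scatter) in this assay is expected to stay within the scatter, with no clear direction. Compound 3 is expected to give about 20000 nM (estimated range 5000 nM to 25000 nM) and may well reach the limit of the assay too.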

Compound 3, half-maximal effective concentration: > 25000 nM
Compound 3: no number, only a limit; the forecaster's own chance of this, stated with the estimate: 65%; at least 1.2-fold (0.09 log units) between middle value and limit.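

In this assay compound 3 gives > 25000 nM as a limit and not a number. Among these compounds, compound 2 also stands at a limit, so no step from compound 2 to compound 3 can be read. What 1,3,4-oxadiazol-2-yl in place of methylamino on a carbonyl carbon does in this assay stays open, as every compound shown stands at one limit: the limit of > 25000 nM in this assay, at which 3 of the 3 values shown sit.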